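Extending the saturated chain: compound 3 to compound 4

This account rests on a few compounds, and the source may have more. Where it says the series, first, only, none or still open, it means among the compounds named here.

- compound 1 `CCCCCC(=O)Nc1nc(N)nc2c1ncn2[C@H]1CO[C@@H](CO)O1`: > 100000 nM
- compound 2 `CCCCCCCC(=O)Nc1nc(N)nc2c1ncn2[C@H]1CO[C@@H](CO)O1`: > 100000 nM
- compound 3 `CCCCCCCCCC(=O)Nc1nc(N)nc2c1ncn2[C@H]1CO[C@@H](CO)O1`: > 100000 nM

In a functional assay on HepG2 cells (Homo sapiens) for cytotoxicity (a higher number here means that more compound is tolerated, a lower number that less compound is tolerated), compound 3 gives > 100000 nM, which is a limit and not a number. It shares this position with the other two compounds: the limit of > 100000 nM in this assay, at which 3 of the 3 values shown sit.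

Compound 4 `CCCCCCCCCCCCCC(=O)Nc1nc(N)nc2c1ncn2[C@H]1CO[C@@H](CO)O1` is the next compound to be measured. It differs from compound 3 by butyl in place of hydrogen on a saturated chain carbon, nine bonds along the chain from a carbonyl carbon.

Within the data shown here, three measured steps bear on this change. The closest is a step that the two limits leave unreadable from compound 1 to compound 3, where butyl enters at five bonds along the chain from a carbonyl carbon. The two ethyl changes are a step that the two limits leave unreadable from compound 1 to compound 2 and a step that the two limits leave unreadable from compound 2 to compound 3. None of these steps has a readable size, so none gives a direction, and they set no firm bound on the change at nine bonds. On this basis, no step beyond the scatter is expected in this assay, and another limit is the most likely report. The expected step is a number no higher from compound 3 to compound 4 (the limit leaves the size open). For compound 4 the estimated value is 100000 nM, with an expected range of 40000 nM to 200000 nM.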

Compound 4, half-maximal cytotoxic concentration: 56000 nM
The estimate for compound 4 lay 1.8-fold (0.25 log units) above the measured number, within the range that was stated.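

In this assay, among these compounds, the butyl at nine bonds along the chain from a carbonyl carbon gives an at least 1.7-fold lower number from compound 3 to compound 4 (0.25 log units; that floor lies within the scatter) and the hexyl at seven bonds along the chain from a carbonyl carbon gives an at least 1.7-fold lower number from compound 2 to compound 4 (0.25 log units; that floor lies within the scatter) and the octyl at five bonds along the chain from a carbonyl carbon gives an at least 1.7-fold lower number from compound 1 to compound 4 (0.25 log units; that floor lies within the scatter) as the first steps with a readable floor. All three floors lie within the scatter, so the chain of compound 4 is not shown to be less tolerated than the shorter chains, and the steps among compound 1, compound 2 and compound 3 cannot be read. What is new is that a number stands in place of a limit at this chain length, and compound 4 alone carries one: the limit of > 100000 nM in this assay, at which 3 of the 4 values shown sit.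

The compounds shown leave open at which chain length a number first appears, and whether a longer chain would take the number down by a step beyond the scatter. Also open, going by these compounds, is how an amine or a carboxylic acid in place of the butyl would read in this assay.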